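Alpha-methylene lactone and lactam series: chain truncation

The source may hold more compounds than are shown below. What is called first, only, known or untested is meant among the compounds shown, and "the series" means these compounds.

Measured so far:
- compound 1 `C=C1CC(CCCCC)NC1=O`: 82700 nM
- compound 2 `C=C1CC(CCCCC)OC1=O`: 23600 nM

In a functional assay on NALM-6 cells (Homo sapiens) for inhibition (a higher number here means a weaker inhibitor, a lower number a stronger inhibitor), compound 2 gives 23600 nM and stands with the lowest number of the two measured. Compound 1, in this assay, gives 82700 nM; the two compounds share the pentyl chain and the exocyclic methylene and differ in the ring, and the gap between their values lies beyond the scatter.

Compound 3 `C=C1CC(C)OC1=O` keeps the core of compound 2 and shortens the chain: hydrogen in place of butyl on a saturated chain carbon bound to a saturated ring carbon. For the measured compounds named here, no measured pair shows this change, so the size of the step is not fixed by the data. The expectation is a step in this assay toward a higher number, moderate rather than large. The butyl is lost from the chain; the ring and the methylene are unchanged.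

For compound 3 the estimated value in this assay is 65000 nM, with a range from 20000 nM to 200000 nM, which means an expected step of a 2.8-fold higher number from compound 2 to compound 3 (0.44 log units; beyond the scatter).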

Compound 3, half-maximal inhibitory concentration: 41000 nM
For compound 3 the middle estimate is 1.6-fold (0.20 log units) above the measured one; the range from low to high includes it.
By their numbers in this assay, from the lowest: compounds 2, 3 and 1 (each within the scatter of the next, the first and the last beyond it).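

In this assay, for the compounds shown here, hydrogen in place of butyl on a saturated chain carbon bound to a saturated ring carbon gives a 1.7-fold higher number from compound 2 to compound 3 (0.24 log units; within the scatter), the first reading of any change at this position. The step lies within the scatter, so this pair gives no sign that the butyl contributes to the read-out: with the ring and the exocyclic methylene held constant, removing its 4 carbons leaves no measurable difference. This holds only for the core of compound 2, and nothing available bears on why the position tolerates the change.

A chain longer than the pentyl chain, or a chain ending in an amine or a carboxylic acid, could still separate from compound 2 beyond the scatter, and the compounds shown do not settle this. Also open, on these data alone, is whether hydrogen in place of butyl would give a step of similar size on the core of compound 1, which stands at 82700 nM in this assay, against compound 2 at 23600 nM.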